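A few compounds are considered here, and "the series" means these few. Any claim that something is new, unique, unknown or untested is made for them only; others in the source may bear on it.

Compound 2 `CCc1cc(C(C)=O)c(O)cc1OCCCCCCC(C)(C)C#N` is the lowest of the three measured compounds in an assay on isolated protein for inhibition of leukotriene B4 receptor 1 (Homo sapiens), tested at 10 uM (on this read-out lower numbers stand for less inhibition and higher numbers for more inhibition at the one concentration tested (going by the name of the read-out)), where compound 2 gives 65%. Compound 1 `CCc1cc(C(C)=O)c(O)cc1OCCCCC(C)(C)C#N` gives 79% and compound 3 `CCc1cc(C(C)=O)c(O)cc1OCCCC(C)(C)C(N)=O` gives 92% in this assay. Compound 4 `CCc1cc(C(C)=O)c(O)cc1OCCCCCC(C)(C)c1nnn(C)n1` differs from compound 2 by 1-methyl-1-(2-methyl-2H-tetrazol-5-yl)ethyl in place of 2-cyano-2-methylpropyl on a saturated chain carbon, five bonds along the chain from an oxygen on an aromatic ring. Among the measured compounds shown here, no measured step exchanges the nitrile for a ring, so the nearest guides are the chain shortening seen as a number 14 percentage points lower from compound 1 to compound 2 (beyond the scatter) and the gain of acceptors seen as a number 27 percentage points higher from compound 2 to compound 3 (beyond the scatter), both modest. The step expected here is a number 5 percentage points higher from compound 2 to compound 4 (within the scatter), a modest rise with wide uncertainty. Compound 4 is therefore estimated at 70% in this assay, within a range from 45% to 90%.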

Compound 4, a percentage reported as inhibition, at one concentration (the size of the read-out at that concentration, not a potency): 95%
The estimate for compound 4 lay 25 percentage points below the measured number; measured number outside the range, above it.
By their numbers in this assay, from the lowest: compound 2; then compound 1; then compounds 3 and 4 (each within the scatter of the next).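

In this assay, putting 1-methyl-1-(2-methyl-2H-tetrazol-5-yl)ethyl in place of 2-cyano-2-methylpropyl gives a number 30 percentage points higher from compound 2 to compound 4 (beyond the scatter) and shows that this place on the chain does not depend on the nitrile. It also accepts a bulkier end group, with 9 heavy atoms instead of 6 and one five-membered aromatic ring. No measurement here explains why the number rises.

As far as these compounds go, whether a carboxylic acid or an amine at this place would give a similar number stays open. So does whether the tetrazole keeps its effect on a shorter or longer chain.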